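The compounds below may be only part of what the source reports. "The series", "measured", "known", "first", "only" and "open" are said of these compounds alone.

Measured so far in an ADME assay on microsomes from liver (Homo sapiens) for metabolic stability, read by LC-MS, using NADPH, with stated times of 5 min and 30 min, tested at 1 uM; on this read-out higher numbers stand for fast clearance and lower numbers for slow clearance

- compound 1 (`Cc1nccn1-c1cnc(NCc2c(F)ccc3c2CCO3)c2cn[nH]c(=O)c12`) gives 8 mL.min-1.g-1
- compound 2 (`O=C1c2ccccc2CN1c1cnc(NCc2c(F)ccc3c2CCO3)n2cnnc12`) gives 13 mL.min-1.g-1

Compound 1 and compound 2 lie within the usual scatter of each other, so these two numbers set no order between them. Together they are the only reference points in this assay, and they differ in more than one place.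

The next compound to be read is compound 3 (`Cc1nc(CO)ccc1-c1cnc(NCc2c(F)ccc3c2CCO3)c2cn[nH]c(=O)c12`). On the core of compound 1, it carries 6-(hydroxymethyl)-2-methylpyridin-3-yl in place of 2-methyl-1H-imidazol-1-yl on an aromatic carbon.

Going by the values given here, no measured pair shows a step of this kind, so there is no direct precedent for its size. The expectation therefore stays close to compound 1 (8 mL.min-1.g-1), with a slight upward lean and no move beyond the scatter. The expected change is a 1.4-fold higher number from compound 1 to compound 3 (0.14 log units; within the scatter) in this assay, and the uncertainty on it is wide. For compound 3 the estimated clearance is 11 mL.min-1.g-1, with an expected range from 5 mL.min-1.g-1 to 24 mL.min-1.g-1.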

Compound 3, intrinsic clearance in microsomes: 11 mL.min-1.g-1
Compound 3: the middle estimate sits on the measured number at the digits printed, and the stated range covers the measured number.
By their numbers in this assay, from the lowest: compounds 1, 3 and 2 (each within the scatter of the next).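

In this assay, going by these compounds alone, the only step readable at this position is a 1.4-fold higher number from compound 1 to compound 3 (0.14 log units; within the scatter), so replacing 2-methyl-1H-imidazol-1-yl with 6-(hydroxymethyl)-2-methylpyridin-3-yl on this aromatic carbon gives no step beyond the scatter. This single pair shows that, on the core of compound 1, a five-membered aromatic ring with 2 hetero atoms can give way to a six-membered aromatic ring with 1 hetero atom, with more heavy atoms and a hydrogen-bond donor that the leaving group lacks, and the clearance reading stays within the scatter; one pair sets no pattern for the series. No available measurement offers an explanation for this outcome.

The ring, its methyl group and its hydroxymethyl group change together in this step, so their separate contributions remain unresolved, and compound 2 differs from compound 1 and compound 3 in more than one place, so it cannot be compared with either. Also open, going by these compounds, is whether the reading would stay within the scatter with a group of another kind here, such as a carboxylic acid, a primary amine or a longer alkyl chain in place of the hydroxymethyl group.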